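The source may report more compounds than this note shows. Statements on the series, on what has been measured and on what is new or still open speak of the compounds shown alone.

Compound 1 `NC(N)=NC(=O)c1nc(Cl)c(NCC2CCCCC2)nc1N`: 96%
Compound 2 `CCCN(C)c1nc(N)c(C(=O)N=C(N)N)nc1Cl`: 91%

In an assay for inhibition of acid-sensing ion channel 3 (Homo sapiens), read by patch clamp, tested at 20 uM (a lower number here means less inhibition, a higher number more inhibition at the concentration tested (going by the name of the read-out)), compound 1 gives 96% and compound 2 gives 91%. Compound 2 stands alongside compound 1: the gap between the two values lies within the usual scatter of repeated measurements, so neither compound can be set above the other on these numbers alone. Both carry the same core and differ only in the group on the aromatic carbon.

Compound 3 `NC(N)=NC(=O)c1nc(Cl)c(Nc2ccccc2)nc1N` is not yet measured. Relative to compound 2 the change is anilino in place of methyl(propyl)amino on an aromatic carbon. For the measured compounds named here, no step between measured compounds is known, so the effect of this change must be judged from the two values above. Because compound 2 gives 91% and compound 1 gives 96%, both near the top of the scale, compound 3 is expected to stay in that region. Compound 3 is estimated at 88%, between 70% and 98%. The step this estimate means, a number 3 percentage points lower from compound 2 to compound 3 (within the scatter), is expected to lie within the scatter, with no clear direction.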

Compound 3, a percentage reported as inhibition, at one concentration (the size of the read-out at that concentration, not a potency): 95%
For compound 3 the middle estimate is 7 percentage points below the measured one; the range from low to high includes it.
By their numbers in this assay, from the lowest: compounds 2, 3 and 1 (each within the scatter of the next).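

In this assay, anilino in place of methyl(propyl)amino on the aromatic carbon next to the ring nitrogen gives a number 4 percentage points higher from compound 2 to compound 3 (within the scatter), so this position accepts an aromatic ring directly on the nitrogen as well as the open chain of compound 2. Phenyl in place of cyclohexylmethyl on that nitrogen gives a number 1 percentage points lower from compound 1 to compound 3 (within the scatter), so in this assay the aromatic and saturated rings cannot be told apart at this position. Nothing in the data explains these readings.

All three compounds read high at a single tested concentration, so any real differences among them stay hidden. As far as these compounds go, whether a plain amino group in place of anilino, or a carboxylic acid on the phenyl ring, would keep this level of inhibition remains open.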